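A fluorine added to the benzylamino arm of compound 1

The source may report more compounds than this note shows. Statements on the series, on what has been measured and on what is new or still open speak of the compounds shown alone.

In a functional assay on HCT-116 cells (Homo sapiens) for cytotoxicity, read by MTT assay, with a stated time of 72 h (a lower number here means a stronger inhibitor, a higher number a weaker inhibitor), compound 1 (`O=C(NCc1ccc(F)cc1)c1nc(Br)c2cccnc2c1NCc1ccccc1`) gives only a limit, > 20000 nM, and no number. The picture is therefore one of weak inhibition at best, as shown by the limit of > 20000 nM in this assay, at which 1 of the 2 values shown sits. For the measured compounds named here, a second compound of the series, compound 2 (`CS(=O)(=O)NCCCCCCN(c1nc(C(=O)NCc2ccc(F)cc2)c(O)c2ncccc12)S(C)(=O)=O`), gives in this assay a measured value of 3000 nM; no single-point step connects it to compound 1, so its value is recorded only for comparison. Compound 3 (`O=C(NCc1ccc(F)cc1)c1nc(Br)c2cccnc2c1NCc1ccc(F)cc1`) has not yet been measured in this assay. It differs from compound 1 by fluoro in place of hydrogen on an aromatic carbon. Such a small change gives no ground to expect a step beyond the usual scatter in this assay, in either direction. The expected step from compound 1 to compound 3 in this assay is accordingly small: a step that the limit leaves unreadable from compound 1 to compound 3. Compound 3 is thus estimated to fall at about 30000 nM, within a range from 8000 nM to 100000 nM, most likely again reported only as a limit.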

Compound 3, half-maximal inhibitory concentration: > 20000 nM
Compound 3 ended at the assay's limit; the forecaster's own chance of this, stated with the estimate: 75%; the middle value lies beyond the limit too.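

In this assay compound 3 gives > 20000 nM, which is a limit and not a number, and compound 1 also stands at a limit, so no step between the two can be read: the limit of > 20000 nM in this assay, at which 2 of the 3 values shown sit.

The compounds shown leave open whether the fluoro group changes cytotoxicity at all.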